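The source may hold more compounds than are shown below. What is called first, only, known or untested is meant among the compounds shown, and "the series" means these compounds.

Measured so far in a functional assay on MKN-45 cells (Homo sapiens) for cytotoxicity, read by MTT assay, with a stated time of 72 h; on this read-out higher numbers stand for weaker inhibition and lower numbers for stronger inhibition:
compound 1 `COc1cc2c(Oc3ccc(NC(=O)c4cc(-c5ccccc5F)ccn4)cc3F)ccnc2cc1OCCCN1CCCCC1`, 180 nM
compound 2 `COc1cc2c(Oc3ccc(NC(=O)c4cc(-c5ccc(C(F)(F)F)cc5)ccn4)cc3F)ccnc2cc1OCCCN1CCCCC1`, 870 nM
compound 3 `COc1cc2c(Oc3ccc(NC(=O)c4cc(-c5ccccc5)ccn4)cc3F)ccnc2cc1OCCCN1CCCCC1`, 270 nM

Compound 3 stands second highest of the three numbers; its gap to compound 1 is within the scatter, while compound 2 sits beyond it, as a 3.2-fold lower number from compound 2 to compound 3 (0.51 log units; beyond the scatter) shows.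

Compound 4 `COc1cc2c(Oc3ccc(NC(=O)c4cc(-c5ccc(C)cc5)ccn4)cc3F)ccnc2cc1OCCCN1CCCCC1` differs from compound 3 by methyl in place of hydrogen on an aromatic carbon, that is, on an aromatic carbon para to a large group. The step that bears most directly is the one at the same place, a 3.2-fold lower number from compound 2 to compound 3 (0.51 log units; beyond the scatter), a modest rise on going from hydrogen to trifluoromethyl there; the other step, a 1.5-fold higher number from compound 1 to compound 3 (0.18 log units; within the scatter), concerns a different position and lies within the scatter. Methyl is a smaller group than trifluoromethyl, so a smaller rise is expected in this assay, a 1.6-fold higher number from compound 3 to compound 4 (0.19 log units; within the scatter), possibly within the scatter. Compound 4 is estimated at 420 nM, with a range of 200 nM to 900 nM.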

Compound 4, half-maximal inhibitory concentration: 1670 nM
For compound 4 the middle estimate is 4.0-fold (0.60 log units) below the measured one; the measured number lies above the stated range.
By their numbers in this assay, from the lowest: compounds 1 and 3 (each within the scatter of the next); then compounds 2 and 4 (each within the scatter of the next).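

In this assay, methyl on the aromatic carbon para to a large group is enough for a clear rise (a 6.2-fold higher number from compound 3 to compound 4 (0.79 log units; beyond the scatter)), and methyl and trifluoromethyl cannot be told apart at this place (a 1.9-fold higher number from compound 2 to compound 4 (0.28 log units; within the scatter)). The widest gap among the compounds shown is 4-methylphenyl against 2-fluorophenyl (a 9.3-fold higher number from compound 1 to compound 4 (0.97 log units; beyond the scatter)). No supporting data bear on why the number rises at this place.

Going by these compounds, whether every group on this carbon raises the number remains open. Only a wider set, such as fluoro, methoxy, an amine or a carboxylic acid there, could show that.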